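A few compounds are considered here, and "the series" means these few. Any claim that something is new, unique, unknown or untested is made for them only; others in the source may bear on it.

Measured compounds:
Compound 1, `CN(C(=O)NC(=O)c1ccc(Cl)cc1Cl)c1nc(C(F)(F)F)c(C(=O)N/N=C/c2cccc(C(F)(F)F)c2)s1`, gives 10.7 ug/mL
Compound 2, `CN(C(=O)NC(=O)c1ccc(Cl)cc1Cl)c1nc(C(F)(F)F)c(C(=O)N/N=C/c2cc(C(F)(F)F)cc(C(F)(F)F)c2)s1`, gives > 100 ug/mL
Compound 3, `CN(C(=O)NC(=O)c1ccc(C(F)(F)F)cc1)c1nc(C(F)(F)F)c(C(=O)N/N=C/c2cccc(C(F)(F)F)c2)s1`, gives 8.95 ug/mL

All three were tested in a functional assay on MCF7 cells (Homo sapiens) for inhibition, read by MTT assay, with a stated time of 72 h; on this read-out higher numbers stand for weaker inhibition and lower numbers for stronger inhibition. The value of compound 2 is a limit of this assay, not a number. Compound 1 and compound 2 share a core and differ in one place: trifluoromethyl in place of hydrogen on an aromatic carbon. That change gave an at least 9.3-fold higher number from compound 1 to compound 2 (0.97 log units; beyond the scatter), so the inhibition became weaker at least to the edge of what this assay can report (the limit of > 100 ug/mL in this assay, at which 1 of the 3 values shown sits).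

Compound 1 and compound 3 differ on the other side of the molecule: 4-(trifluoromethyl)phenyl in place of 2,4-dichlorophenyl on a carbonyl carbon. That change gave a 1.2-fold lower number from compound 1 to compound 3 (0.08 log units; within the scatter), so the two compounds cannot be told apart here.

Compound 4, `CN(C(=O)NC(=O)c1ccc(C(F)(F)F)cc1)c1nc(C(F)(F)F)c(C(=O)N/N=C/c2cc(C(F)(F)F)cc(C(F)(F)F)c2)s1`, has not been measured. It differs from compound 3 by trifluoromethyl in place of hydrogen on an aromatic carbon, which is the same change that turns compound 1 into compound 2, made on the core of compound 3. The surroundings of the place are described in identical words in both cases.

Compound 4 is therefore expected to behave as compound 2 did, with a step of an 11-fold higher number from compound 3 to compound 4 (1.05 log units; beyond the scatter), because the same change gave an at least 9.3-fold higher number from compound 1 to compound 2 (0.97 log units; beyond the scatter). Compound 4 is estimated to give 100 ug/mL in this assay, with a fair chance that only a limit is reported, as for compound 2; the range from 40 ug/mL to 300 ug/mL is an expectation that rests on compound 1, compound 2 and compound 3 alone.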

Compound 4, half-maximal inhibitory concentration: 7.37 ug/mL
For compound 4 the middle estimate is 14-fold (1.13 log units) above the measured one, and the stated range ends above it.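

In this assay the added trifluoromethyl gave a 1.2-fold lower number from compound 3 to compound 4 (0.08 log units; within the scatter) and so left the two compounds indistinguishable, which means the large loss of inhibition seen on the core of compound 1 did not carry over to the core of compound 3: the same change on two cores in this assay, an at least 9.3-fold higher number (0.97 log units; beyond the scatter) from compound 1 to compound 2 and a 1.2-fold lower number (0.08 log units; within the scatter) from compound 3 to compound 4, at least 11-fold (1.05 log units) apart, beyond the scatter of two such steps.

The exchange of 2,4-dichlorophenyl for 4-(trifluoromethyl)phenyl likewise depended on its partner, giving an at least 13-fold lower number from compound 2 to compound 4 (1.13 log units; beyond the scatter) on the cores that hold the added trifluoromethyl, a clear step where the same exchange had made no readable difference before: the same change on two cores in this assay, a 1.2-fold lower number (0.08 log units; within the scatter) from compound 1 to compound 3 and an at least 13-fold lower number (1.13 log units; beyond the scatter) from compound 2 to compound 4, at least 11-fold (1.05 log units) apart, beyond the scatter of two such steps.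

Compound 2 has only a limit of the assay (> 100 ug/mL), so the true size of these gaps is unknown, and these four compounds show that the two changes do not simply add up in this series but not why they fail to.

The compounds shown leave open whether the sharp loss on the core of compound 1 is tied to trifluoromethyl itself or would also appear with another group at the same place, such as chlorine, a methoxy group or an amine. They also leave open whether a different group on the carbonyl carbon, such as an unsubstituted phenyl, would protect inhibition in the way 4-(trifluoromethyl)phenyl did.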